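The source may report more compounds than this note shows. Statements on the series, on what has been measured and on what is new or still open speak of the compounds shown alone.

Compound 1 `Cc1cc(C)c(Oc2cc(Nc3ccc(C#N)cc3)ncc2C(=O)NCc2cn(Cc3ccccc3C#N)nn2)c(C)c1` in an ADME assay on MT4 cells (Homo sapiens) for cytotoxicity, read by MTT assay, with a stated time of 5 days (on this read-out lower numbers stand for higher toxicity in this test and higher numbers for lower toxicity in this test), gives > 219000 nM, a limit of the assay.
Compound 2 `COC(=O)Cn1cc(CNC(=O)c2cnc(Nc3ccc(C#N)cc3)cc2Oc2c(C)cc(C)cc2C)nn1` in this assay gives 13800 nM.
Compound 3 `Cc1cc(C)c(Oc2cc(Nc3ccc(C#N)cc3)ncc2C(=O)NCc2cn(Cc3ccccc3C)nn2)c(C)c1` in this assay gives >= 164000 nM, again a limit.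

Compound 3 therefore stands at the upper edge of what the test can read, as the line the limit of >= 164000 nM in this assay, at which 1 of the 3 values shown sits, shows, while compound 1 sits at the other limit, (the limit of > 219000 nM in this assay, at which 1 of the 3 values shown sits). Within the data shown here, the only compound with a proper number, compound 2, lies far lower: an at least 11-fold higher number from compound 2 to compound 3 (1.07 log units; beyond the scatter). The step that the two limits leave unreadable from compound 1 to compound 3, by contrast, cannot be sized.

Compound 4 `Cc1cc(C)c(Oc2cc(Nc3ccc(C#N)cc3)ncc2C(=O)NCc2cn(Cc3ccccc3Cl)nn2)c(C)c1` differs from compound 3 by chloro in place of methyl on an aromatic carbon. Among the measured compounds shown here, no measured step replaces one small substituent on that benzyl ring by another; the readable step of an at least 15-fold lower number from compound 1 to compound 2 (1.20 log units; beyond the scatter) and an at least 11-fold higher number from compound 2 to compound 3 (1.07 log units; beyond the scatter) both exchange the whole 2-substituted phenyl for a methoxycarbonyl, which is a far larger change than a methyl going to a chloro. With compound 3 already at a limit and compound 1, carrying a cyano at the same spot, likewise at a limit, compound 4 is expected to remain in the same region, with a step of an at least 1.0-fold lower number from compound 3 to compound 4 (0.01 log units; that floor lies within the scatter), that is, none beyond the scatter. Compound 4 is accordingly estimated at 160000 nM, between 60000 nM and 250000 nM, most likely reported again only as a limit.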

Compound 4, half-maximal cytotoxic concentration: >= 188000 nM
Compound 4: a limit, no number; the forecaster's own chance of this, stated with the estimate: 70%; middle value at least 1.1-fold (0.07 log units) away from the limit.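

With chloro in place of methyl, compound 4 in this assay also ends at a limit and gives no number: the limit of >= 188000 nM in this assay, at which 1 of the 4 values shown sits. Chloro is thus a third small group on this aromatic carbon, after cyano in compound 1 and methyl in compound 3, to leave the read-out at a limit; the steps among these three compounds cannot be read, so no order among the three groups can be given. Among these compounds, the only readable step, an at least 13-fold higher number from compound 2 to compound 4 (1.13 log units; beyond the scatter), extends to the 2-chlorobenzyl group the large separation from the methoxycarbonyl group already seen with the 2-cyanobenzyl and 2-methylbenzyl groups.

The compounds shown leave open whether any group on this benzyl ring, such as an amine or a carboxylic acid in place of the chloro, would bring the read-out down to a proper number. They also leave open whether the lower number belongs to the ester itself or to the absence of the phenyl ring, a question that a carboxylic acid or a plain ethyl group on the same saturated chain carbon would address.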